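Inverting a ring stereocentre on the cyclobutyl amine

This account rests on a few compounds, and the source may have more. Where it says the series, first, only, none or still open, it means among the compounds named here.

Of the compounds shown here, three sharing one core have been measured in an assay on isolated protein for inhibition of protein kinase C delta type (Homo sapiens), read by TR-FRET, with a stated time of 2 h; on this read-out lower numbers stand for stronger inhibition and higher numbers for weaker inhibition. Compound 1 `N#Cc1cnc(NCc2cnccc2C(F)(F)F)cc1NC[C@H]1CC[C@@H](O)CC1` gives 500 nM, compound 2 `N#Cc1cnc(NCc2cnccc2C(F)(F)F)cc1NC1CCOCC1` gives 9800 nM, and compound 3 `CC1(C)[C@H](Nc2cc(NCc3cnccc3C(F)(F)F)ncc2C#N)C[C@H]1C(N)=O` gives 900 nM. Compound 3 thus holds the second highest of the three numbers: it sits near compound 1, with a 1.8-fold higher number from compound 1 to compound 3 (0.26 log units; within the scatter), and far from compound 2, with an 11-fold lower number from compound 2 to compound 3 (1.04 log units; beyond the scatter). The remaining measured step, a 20-fold higher number from compound 1 to compound 2 (1.29 log units; beyond the scatter), is also large.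

Compound 4 `CC1(C)[C@@H](Nc2cc(NCc3cnccc3C(F)(F)F)ncc2C#N)C[C@H]1C(N)=O` is the next compound to be measured. Its relation to compound 3 is the two compounds have the same atoms and bonds and differ only in configuration as drawn: 1 of 2 stereo elements differ; a stereocentre at a saturated ring carbon is drawn R in compound 3 and S in compound 4. None of the three measured steps concerns a change of configuration; each of them exchanges one whole substituent on the aromatic nitrogen for another. The data therefore give no direct guide to the size or direction of the step to compound 4 in this assay, and an inverted stereocentre on a saturated ring may leave the number roughly where it is or move it considerably. Compound 4 is accordingly expected to give about 1800 nM, within a wide band from 400 nM to 9000 nM. The expected step is a 2.0-fold higher number from compound 3 to compound 4 (0.30 log units; within the scatter), leaning toward a weaker number than compound 3 but with low confidence.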

Compound 4, half-maximal inhibitory concentration: 4500 nM
The estimate for compound 4 lay 2.5-fold (0.40 log units) below the measured number; the measured number falls inside the stated range.
By their numbers in this assay, from the lowest: compounds 1 and 3 (each within the scatter of the next); then compound 4; then compound 2.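

In this assay, among the compounds shown here, the configuration at this saturated ring carbon of the 3-carbamoyl-2,2-dimethylcyclobutyl group matters in its own right: changing it from R to S gives a 5.0-fold higher number from compound 3 to compound 4 (0.70 log units; beyond the scatter), the first step in this set in which no atoms or bonds change. The same group therefore does not carry its earlier standing with it. Whereas the R form lay within the scatter of the (4-hydroxycyclohexyl)methyl compound, the S form gives a 9.0-fold higher number from compound 1 to compound 4 (0.95 log units; beyond the scatter), and its margin over the oxan-4-yl compound narrows to a 2.2-fold lower number from compound 2 to compound 4 (0.34 log units; beyond the scatter), against an 11-fold lower number from compound 2 to compound 3 (1.04 log units; beyond the scatter) for the R form. The shift can be assigned to this one stereocentre alone, because nothing else separates the pair: the fact that compounds 3 and 4 differ only in the configuration as drawn.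

The compounds shown leave open how the second stereo element, drawn alike in compound 3 and compound 4, affects the number, and why the inversion moves it at all. They also leave open whether the same sensitivity to configuration would persist if the carbamoyl group gave way to a carboxylic acid or an amine.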